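Replacing a formyl ester with a 4-nitrobenzyl ester

The compounds below may be only part of what the source reports. "The series", "measured", "known", "first", "only" and "open" are said of these compounds alone.

Measured so far:
compound 1 `CCOC(=O)C1=C(C)NC(C)=C(C(=O)OCCOC)C1c1cccc([N+](=O)[O-])c1` gives 82 nM in a functional assay on HEK293 cells for antagonist activity at Voltage-dependent L-type calcium channel subunit alpha-1D (Rattus norvegicus), read by FLIPR; a lower number here means a stronger inhibitor, a higher number a weaker inhibitor;
compound 2 `CCOC(=O)C1=C(C)NC(C)=C(C(=O)OC=O)C1c1cccc([N+](=O)[O-])c1` gives 13900 nM.

Compound 2 stands highest of the two numbers; its nearest neighbour is compound 1, and the change of a 170-fold higher number from compound 1 to compound 2 (2.23 log units; beyond the scatter) lies well beyond the scatter. Compound 3 `CCOC(=O)C1=C(C)NC(C)=C(C(=O)OCc2ccc([N+](=O)[O-])cc2)C1c1cccc([N+](=O)[O-])c1` is not yet measured. It differs from compound 2 by 4-nitrobenzyl in place of formyl on an oxygen next to a carbonyl group. Within the data shown here, the only step that bears on this change is a 170-fold higher number from compound 1 to compound 2 (2.23 log units; beyond the scatter), which shows that a formyl group in this place gives a much weaker inhibitor than a longer ester chain. Compound 3 is therefore expected to return toward compound 1, with an estimated step of a 93-fold lower number from compound 2 to compound 3 (1.97 log units; beyond the scatter); the estimate for compound 3 is 150 nM, with a range from 20 nM to 1500 nM.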

Compound 3, half-maximal inhibitory concentration: 140 nM
Beside the measured number, compound 3's estimate is 1.1-fold (0.03 log units) above it, within the range that was stated.
By their numbers in this assay, from the lowest: compounds 1 and 3 (each within the scatter of the next); then compound 2.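

Putting 4-nitrobenzyl in place of formyl brings a 99-fold lower number from compound 2 to compound 3 (2.00 log units; beyond the scatter) and so recovers the strength lost with the formyl ester, while the comparison with the 2-methoxyethyl ester gives a 1.7-fold higher number from compound 1 to compound 3 (0.23 log units; within the scatter) and separates those two groups by no real margin. This place on the oxygen therefore accepts two very different groups, one with an aromatic ring and one a chain, and of the three only formyl stands apart. Nothing measured here explains why the formyl ester differs. Going by these compounds, whether the nitro group on the benzyl ring matters remains open, as a plain benzyl ester would be needed to tell. On these data alone, how a short methyl ester, an amide or a free carboxylic acid would behave here also remains unknown.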